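The source may hold more compounds than are shown below. What is called first, only, known or untested is meant among the compounds shown, and "the series" means these compounds.

Measured in a functional assay on CLL cells (Homo sapiens) for cytotoxicity, read by MTT assay, with a stated time of 48 h; a lower number here means that less compound is needed, a higher number that more compound is needed for the effect:
- Compound 1 `C=C(CC)C(=O)c1ccc(OCC(=O)Nc2ccc(C(=O)O)cn2)c(Cl)c1Cl`: 14900 nM
- Compound 2 `C=C(CC)C(=O)c1ccc(OCC(=O)Nc2ccc(S(=O)(=O)O)cc2)c(Cl)c1Cl`: > 25000 nM (a limit of the assay)

In this assay, compound 2 stands at > 25000 nM, which is a limit and not a number. The record therefore shows (the limit of > 25000 nM in this assay, at which 1 of the 2 values shown sits). Within the data shown here, the only actual number is that of compound 1, at 14900 nM.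

Compound 3 `C=C(CC)C(=O)c1ccc(OCC(=O)Nc2ccc(C(C)=O)cc2)c(Cl)c1Cl` keeps the rest of compound 2 and carries acetyl in place of sulfo on an aromatic carbon, para to a large group: acetyl in place of sulfo on an aromatic carbon. Among the measured compounds shown here, no measured step between two compounds shows what such a change does, so any expectation here is tentative. For the measured compounds named here, a move beyond the scatter toward a lower concentration in this assay is expected, into the range of numbers that the assay can report, with compound 1 at 14900 nM as the only numerical guide. The estimated size of this move is an at least 3.1-fold lower number from compound 2 to compound 3 (0.49 log units; beyond the scatter). For compound 3 the expected value is 8000 nM, with an estimated range of 2000 nM to 24000 nM.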

Compound 3, half-maximal effective concentration: 3900 nM
The estimate for compound 3 lay 2.1-fold (0.31 log units) above the measured number; measured number inside the range.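

At this position, an aromatic carbon para to a large group, acetyl in place of sulfo gives an at least 6.4-fold lower number from compound 2 to compound 3 (0.80 log units; beyond the scatter) in this assay and so shows that a group here can bring a compound into the range of numbers that the assay reports. The comparison with compound 1, with 4-acetylphenyl in place of 5-carboxypyridin-2-yl on an amide-type nitrogen, gives a 3.8-fold lower number from compound 1 to compound 3 (0.58 log units; beyond the scatter) and is the first step shown that joins two actual numbers, so compound 3 is placed against a measured neighbour and not only against a limit. The step from compound 2 gives only a lower bound on the size of the change, because one of its two ends is a limit of the assay and not a number: the limit of > 25000 nM in this assay, at which 1 of the 3 values shown sits.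

The compounds shown leave open whether a carboxylic acid, an amine or a methyl ester at this same position of the carbon-only ring would read closer to acetyl or to sulfo. They also leave open how the step from compound 1 divides between the change of ring and the change of group, as the two change together there.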